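The source may hold more compounds than are shown below. What is called first, only, known or untested is meant among the compounds shown, and "the series" means these compounds.

In an ADME assay on HOS cells (Homo sapiens) for cytotoxicity (a higher number here means that more compound is tolerated, a lower number that less compound is tolerated), compound 3 `CN(Cc1nc2cccc(C(=O)NCCCN)c2[nH]1)C1CCCc2cccnc21` stands only as a limit, > 20000 nM. Compound 1 `CN(Cc1nc2ccccc2n1CCN)C1CCCc2cccnc21` is likewise a limit, > 20000 nM. Compound 2 `CN(C)CCCn1c(CN(C)C2CCCc3cccnc32)nc2ccccc21` gives a number, 16800 nM. Within the data shown here, the one measured step, an at least 1.1-fold lower number from compound 1 to compound 2 (0.07 log units; that floor lies within the scatter), stays within the scatter and concerns a different place on the molecule, and the values shown gather at the limit of > 20000 nM in this assay, at which 2 of the 3 values shown sit. Compound 4 `CN(Cc1nc2cccc(CCCN)c2[nH]1)C1CCCc2cccnc21` carries 3-aminopropyl in place of (3-aminopropyl)carbamoyl on an aromatic carbon, (3-aminopropyl in place of (3-aminopropyl)carbamoyl on an aromatic carbon). Among the measured compounds shown here, no measured step covers this change, so with only the small step to compound 2 as a guide, no shift beyond the scatter is expected. The expected step is an at least 1.0-fold lower number from compound 3 to compound 4 (0.02 log units; that floor lies within the scatter). The estimate for compound 4 is 19000 nM, with an expected range of 10000 nM to 30000 nM.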

Compound 4, half-maximal cytotoxic concentration: 10000 nM
Estimate against measurement, compound 4: 1.9-fold (0.28 log units) above; the measured number falls inside the stated range.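

The exchange of (3-aminopropyl)carbamoyl for 3-aminopropyl on this aromatic carbon gives the first step read at this position in this assay: an at least 2.0-fold lower number from compound 3 to compound 4 (0.30 log units; that floor lies within the scatter). This is only a floor and does not show a change beyond the scatter, because compound 3 stands at a limit of the assay: the limit of > 20000 nM in this assay, at which 2 of the 4 values shown sit.

The compounds shown leave open how a longer chain or a terminal carboxylic acid in place of the amine would read on this aromatic carbon. They also leave open whether a ketone, which keeps the carbonyl without the amide hydrogen, would read like compound 3 or compound 4.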